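Cyclic phosphorus core: trifluoromethyl in place of chloro

The compounds below may be only part of what the source reports. "The series", "measured", "known", "first", "only" and "open" are said of these compounds alone.

Two compounds have numbers in a functional assay on L1210 cells (Mus musculus) for antiproliferative activity; a higher number here means a weaker inhibitor, a lower number a stronger inhibitor. Compound 1 `O=c1[nH]c(=O)n([C@H]2C[C@H](O)[C@@H](COP(=O)(O)O)O2)cc1C(F)(F)F` gives 0.017 ug/mL. Compound 2 `O=c1[nH]c(=O)n([C@H]2C[C@@H]3O[PH](O)(O)OC[C@H]3O2)cc1Cl` gives 337 ug/mL, the higher of the two numbers; its core differs from that of compound 1, so the two values stand side by side without a single-point comparison. Compound 3 `O=c1[nH]c(=O)n([C@H]2C[C@@H]3O[PH](O)(O)OC[C@H]3O2)cc1C(F)(F)F` keeps the core of compound 2 and differs from it only in one place: trifluoromethyl in place of chloro on an aromatic carbon. Among the measured compounds shown here, no measured step of this kind exists. Compound 3 is expected to give 150 ug/mL, between 15 ug/mL and 800 ug/mL, which means an expected step of a 2.2-fold lower number from compound 2 to compound 3 (0.35 log units; beyond the scatter), likely no larger than the scatter or a modest move toward the lower end.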

Compound 3, concentration for 50% inhibition: 0.116 ug/mL
The estimate for compound 3 lay 1300-fold (3.11 log units) above the measured number; the measured number lies below the stated range.
By their numbers in this assay, from the lowest: compound 1; then compound 3; then compound 2.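

On the core shared by compound 2 and compound 3, the group on this aromatic carbon has a large effect in this assay: trifluoromethyl in place of chloro gives a 2900-fold lower number from compound 2 to compound 3 (3.46 log units; beyond the scatter) in this series. The high number of compound 2 therefore cannot be assigned to the core alone. No measurement at hand explains the size of this step.

Open, from the compounds shown here alone, is whether bromo, methyl or nitrile on this carbon would read like chloro or like trifluoromethyl. Also open, going by these compounds, is whether chloro on the core of compound 1 would produce a step of similar size.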